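Swapping the carbamate-side group for a difluoropropyl chain

A few compounds are considered here, and "the series" means these few. Any claim that something is new, unique, unknown or untested is made for them only; others in the source may bear on it.

Of the compounds shown here, three sharing one core have been measured in a functional assay on isolated protein for inhibition of Glucose-dependent insulinotropic receptor (Rattus norvegicus), read by HTRF and cAMP accumulation; on this read-out lower numbers stand for smaller maximal responses and higher numbers for larger maximal responses. Compound 1 `Cc1nc(S(C)(=O)=O)ccc1Oc1ncnc(OC2CCN(C(=O)OC(C)(C)CF)CC2)c1F` gives 95%, compound 2 `Cc1nc(S(C)(=O)=O)ccc1Oc1ncnc(OC2CCN(C(=O)O[C@H](C)CF)CC2)c1F` gives 79%, and compound 3 `Cc1nc(S(C)(=O)=O)ccc1Oc1ncnc(OC2CCN(C(=O)SC3(C)CC3)CC2)c1F` gives 77%. Compound 3 therefore stands lowest of the three; its gap to compound 2 is within the scatter, while the step of a number 18 percentage points lower from compound 1 to compound 3 (beyond the scatter) is beyond it.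

Compound 4 `CCC(F)(F)C(=O)N1CCC(Oc2ncnc(Oc3ccc(S(C)(=O)=O)nc3C)c2F)CC1` has not yet been measured. It differs from compound 3 in one place: a group of 5 heavy atoms (3 carbon, 2 fluorine; no ring) in place of a group of 5 heavy atoms (4 carbon, 1 sulfur; one three-membered non-aromatic ring of carbon only), on a carbonyl carbon.

Going by the values given here, two measured steps bear on this change, since both alter the group on the same carbonyl carbon. The step of a number 18 percentage points lower from compound 1 to compound 3 (beyond the scatter) shows that moving from a fluorinated, ring-free group to the ring-containing sulfur group lowered the maximal response modestly, whereas a number 2 percentage points lower from compound 2 to compound 3 (within the scatter) shows a smaller fluorinated, ring-free group giving practically the same response as the ring-containing group. Compound 4 returns to a fluorinated, ring-free group, though one without the oxygen present in compounds 1 and 2, so a small upward step is expected, not clearly beyond the scatter. The step expected from compound 3 to compound 4 is a number 7 percentage points higher from compound 3 to compound 4 (within the scatter). Compound 4 is therefore estimated at 84%, with a likely range from 68% to 98%.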

Compound 4, largest response reached (reported as efficacy), in percent of the reference or control that the assay uses: 90%
Compound 4: middle estimate off by 6 percentage points, on the low side; the measured number falls inside the stated range.
By their numbers in this assay, from the lowest: compounds 3 and 2 (each within the scatter of the next); then compounds 4 and 1 (each within the scatter of the next).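

In this assay, putting the 1,1-difluoropropyl group on the carbonyl carbon gives a number 13 percentage points higher from compound 3 to compound 4 (beyond the scatter) and a number 11 percentage points higher from compound 2 to compound 4 (beyond the scatter). Going by these compounds alone, this shows that the group at this position need not reach the carbonyl through an oxygen or a sulfur for a large maximal response, which the earlier compounds could not show because all of them carried one of those two atoms there. The comparison with the 1-(fluoromethyl)-1-methylethyl group gives a number 5 percentage points lower from compound 1 to compound 4 (within the scatter), so these two groups cannot be told apart on this read-out, and nothing shown here explains why the groups differ as they do.

On these data alone, how a plain propyl chain, with no fluorine, or a longer chain such as 1,1-difluorobutyl would compare with the 1,1-difluoropropyl group remains open, so the part played by the two fluorines and by chain length is unsettled. Also open, as far as these compounds go, is whether an amine on the same carbonyl carbon, which would make a urea, keeps the response, and how any of these groups would behave on a read-out of potency rather than largest response.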